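A few compounds are considered here, and "the series" means these few. Any claim that something is new, unique, unknown or untested is made for them only; others in the source may bear on it.

In a functional assay on MCF7 cells (Homo sapiens) for cytotoxicity, read by MTT assay, with a stated time of 72 h (a lower number here means a stronger inhibitor, a higher number a weaker inhibitor), compound 2 `COc1ccc(C(=O)NC[C@H]2c3[nH]c4ccccc4c3C[C@H]3[C@H]4c5[nH]c6ccccc6c5C[C@@H]([C@H](C#N)N23)N4C)cc1` gives 600 nM, and compound 1 `CN1[C@@H]2c3[nH]c4ccccc4c3C[C@H]1[C@H](C#N)N1[C@@H](CN3C(=O)c4ccccc4C3=O)c3[nH]c4ccccc4c3C[C@@H]21` gives 610 nM; the two numbers lie within the scatter of each other, so compound 2 stands apart from nothing. Going by the values given here, the only step measured, a 1.0-fold lower number from compound 1 to compound 2 (0.01 log units; within the scatter), concerned a group elsewhere in the molecule. Compound 3 `CN1[C@@H]2c3[nH]c4ccccc4c3C[C@H]1[C@H](C#N)N1[C@@H](CNC(=O)c3ccc(F)cc3)c3[nH]c4ccccc4c3C[C@@H]21` differs from compound 2 by fluoro in place of methoxy on an aromatic carbon. Among the compounds with values here, no measured step touches that position, so there is no basis for expecting a step beyond the scatter; the expected step is no change at the digits printed from compound 2 to compound 3 (within the scatter). Compound 3 is therefore estimated at 600 nM, within a range of 250 nM to 1500 nM.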

Compound 3, half-maximal inhibitory concentration: 980 nM
The estimate for compound 3 lay 1.6-fold (0.21 log units) below the measured number; low and high end bracket the measured number.
By their numbers in this assay, from the lowest: compounds 2, 1 and 3 (each within the scatter of the next).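

In this assay fluoro in place of methoxy on the aromatic ring, para to a large group, gives a 1.6-fold higher number from compound 2 to compound 3 (0.21 log units; within the scatter) and so does not separate the two compounds. The wider replacement gives a 1.6-fold higher number from compound 1 to compound 3 (0.21 log units; within the scatter) and likewise stays inside the scatter, so none of the three side groups on the chain carbon stands apart here. No evidence is available that bears on this result. From the compounds shown here alone, with only methoxy and fluoro compared at this ring position, it remains open whether any substituent there can move the number beyond the scatter. An amine or a carboxylic acid in that place could test this.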